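The compounds below may be only part of what the source reports. "The series", "measured", "known", "first", "only" and "open" are said of these compounds alone.

Measured so far in a functional assay on NCI-H460 cells (Homo sapiens) for inhibition, read by MTT assay, with a stated time of 24 h, tested at 1 ug/mL; on this read-out lower numbers stand for less inhibition of growth and higher numbers for more inhibition of growth at the one concentration tested:

compound 1, `CC(=O)SCCC(CCCCC(=O)Nc1ccccc1)SC(C)=O` — 13.1%
compound 2, `CC(=O)SCCC(CCCCC(=O)Nc1ccc(Cl)cc1)SC(C)=O` — 15.4%
compound 3, `O=C(CCCCC(CCSC(=O)c1ccccc1)SC(=O)c1ccccc1)Nc1ccccc1` — 5.93%

Compounds 1 and 2 share one core; compound 3 carries a different one, and the difference between the two cores is not broken down here. Compound 3 has the lowest of the three numbers, yet its gap to compound 1 and to compound 2 is each within the scatter, so none of the three can be set apart from the others in this assay.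

Within the data shown here, the one step that can be read directly is chloro in place of hydrogen on an aromatic carbon, which gave a number 2.3 percentage points higher from compound 1 to compound 2 (within the scatter). The same kind of change is now made on the core of compound 3 to give compound 4, `O=C(CCCCC(CCSC(=O)c1ccccc1)SC(=O)c1ccccc1)Nc1ccccc1Cl`, namely (chloro in place of hydrogen on an aromatic carbon). The two changes are not the same: in compound 2 the chloro sits para to a large group, in compound 4 it sits ortho to a large group. Among the measured compounds shown here, only one measured example of a chloro entering an aromatic carbon exists in the set, and it sits on another core and at another place, so it carries little weight.

For compound 4 in this assay a step of a number 2.1 percentage points higher from compound 3 to compound 4 (within the scatter) is expected, resting on the step from compound 1 to compound 2 having stayed within the scatter. The estimate for compound 4 is therefore 8%, with a range from 0% to 20%.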

Compound 4, percent growth inhibition at one concentration: 14.4%
Beside the measured number, compound 4's estimate is 6.4 percentage points below it; the range from low to high includes it.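

In this assay, chloro in place of hydrogen on an aromatic carbon gave a number 8.5 percentage points higher from compound 3 to compound 4 (within the scatter), so on the core of compound 3, as on the core of compound 1, the change cannot be separated from repeat-to-repeat variation. Set side by side, the two steps do not differ measurably between the cores: the same change on two cores in this assay, a number 2.3 percentage points higher (within the scatter) from compound 1 to compound 2 and a number 8.5 percentage points higher (within the scatter) from compound 3 to compound 4, 6.2 percentage points apart, within the scatter of two such steps

Among these compounds, this agreement shows only that neither pair gives a step beyond the scatter; it does not show that chloro raises the number on either core, that the step carries over with a fixed size, or that core and place on the ring act independently, as the chloro of compound 4, as part of a 2-chlorophenyl group, stands ortho to a large group and the chloro of compound 2 stands at another place.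

The compounds shown leave open whether a methoxy or nitro group on the same aromatic ring would give a step beyond the scatter on either core. Also open, on these data alone, is how the series would read in this assay with free thiols in place of the thioesters, or with a longer chain between the amide carbonyl and the sulfur-bearing carbon.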